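Benzylthio purine ribosides: alkylamino chain to cyclopentylamino

A few compounds are considered here, and "the series" means these few. Any claim that something is new, unique, unknown or untested is made for them only; others in the source may bear on it.

Measured so far in an assay on cell membranes for binding affinity to Equilibrative nucleoside transporter 1 (Homo sapiens); on this read-out higher numbers stand for weaker inhibition and lower numbers for stronger inhibition:
compound 1, `CCNc1nc2c(SCc3ccccc3)ncnc2n1C1O[C@H](CO)[C@@H](O)[C@H]1O`: 9.5 nM
compound 2, `CCCCNc1nc2c(SCc3ccccc3)ncnc2n1C1O[C@H](CO)[C@@H](O)[C@H]1O`: 5.4 nM
compound 3, `CCCCCNc1nc2c(SCc3ccccc3)ncnc2n1C1O[C@H](CO)[C@@H](O)[C@H]1O`: 2.3 nM

The three compounds share one core and differ only in the alkyl group on the exocyclic nitrogen. Compound 3 gives the lowest number of the three, with the gap to its nearest neighbour beyond the scatter: a 2.3-fold lower number from compound 2 to compound 3 (0.37 log units; beyond the scatter) and a 4.1-fold lower number from compound 1 to compound 3 (0.62 log units; beyond the scatter). The smaller step of a 1.8-fold lower number from compound 1 to compound 2 (0.25 log units; within the scatter) stays within the scatter. Longer chain, lower number, is the whole of the pattern so far, with no compound going against it.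

Compound 4, `OC[C@H]1OC(n2c(NC3CCCC3)nc3c(SCc4ccccc4)ncnc32)[C@H](O)[C@@H]1O`, keeps the same core and the same nitrogen. The change is cyclopentyl in place of pentyl on a nitrogen on an aromatic ring. For the measured compounds named here, none of the measured steps covers a chain closed into a ring; all three concern chain length only. Going by the values given here, with the atom count held, the chain-length steps suggest no large move, and there is no precedent for the ring itself, so a number close to that of compound 3 is the expectation, with the uncertainty widened on both sides. The step of a 1.1-fold higher number from compound 3 to compound 4 (0.04 log units; within the scatter) is thus expected to fall within the scatter. For compound 4 the estimate in this assay is 2.5 nM, with a range from 0.9 nM to 7 nM.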

Compound 4, inhibition constant: 0.64 nM
The estimate for compound 4 lay 3.9-fold (0.59 log units) above the measured number; measured number outside the range, below it.
By their numbers in this assay, from the lowest: compound 4; then compound 3; then compounds 2 and 1 (each within the scatter of the next).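

In this assay the shape of the group on the nitrogen counts as well as its length: the pentyl and cyclopentyl groups have the same count of heavy atoms, yet closing the chain into a ring gives a lower number (a 3.6-fold lower number from compound 3 to compound 4 (0.56 log units; beyond the scatter)), so the trend no longer depends on adding carbon. Against the shorter chains, the ring gives larger steps (an 8.4-fold lower number from compound 2 to compound 4 (0.93 log units; beyond the scatter) and a 15-fold lower number from compound 1 to compound 4 (1.17 log units; beyond the scatter)), the second being the only step in the series rated large, and compound 4 now has the lowest number, with its steps to all three others beyond the scatter. No measurement at hand accounts for the gain from closing the ring.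

As far as these compounds go, it remains open whether the ring size is itself important, as a cyclobutyl or cyclohexyl group on the same nitrogen would show, and whether a branched group such as isopropyl or a longer chain such as hexyl would come close to compound 4. Also open, from the compounds shown here alone, is whether the advantage of cyclopentylamino over pentylamino persists when the benzyl group on sulfur is replaced, for example by a 4-nitrobenzyl group.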